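The compounds below may be only part of what the source reports. "The series", "measured", "known", "first", "only" and "open" are said of these compounds alone.

The three compounds measured so far:

Compound 1 `CCC1C(=O)N(C)c2cnc(-n3ccc4cc(C(N)=O)ccc43)nc2N1c1ccn(C)n1` gives 39500 nM in a functional assay on A549 cells (Homo sapiens) for antiproliferative activity, read by CCK-8 assay, with a stated time of 72 h; on this read-out higher numbers stand for weaker inhibition of growth and lower numbers for stronger inhibition of growth.
Compound 2 `CC[C@@H]1C(=O)N(C)c2cnc(Nc3ccc(S(=O)(=O)NCCO)cc3)nc2N1C1CCCC1` gives 563 nM in this assay.
Compound 3 `CCCCNS(=O)(=O)c1ccc(Nc2ncc3c(n2)N(c2ccn(C)n2)C(CC)C(=O)N3C)cc1` gives 10600 nM in this assay.

Compound 1 stands highest of the three numbers in this assay, that is, it is the weakest inhibitor of growth among them. Compound 3 sits nearest to it, yet the gap between the two lies beyond the scatter; compound 2 lies furthest away, far beyond the scatter. Neither of those two shares a single-point difference with compound 1, so nothing can be said about what separates them beyond their values.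

Compound 4 `CCC1C(=O)N(C)c2cnc(-n3ccc4cc(C(=O)NC(C)C)ccc43)nc2N1c1ccn(C)n1` is the next compound to be tested. It differs from compound 1 in one place: isopropyl in place of hydrogen on an amide-type nitrogen. Going by the values given here, no pair among the measured compounds shows this kind of change, so there is no direct guide to its size. In this assay the step that is expected is a 1.6-fold lower number from compound 1 to compound 4 (0.20 log units; within the scatter), a modest change, most likely toward stronger inhibition of growth, of a size that may not exceed the scatter. Compound 4 is therefore estimated at 25000 nM, with a range from 8000 nM to 80000 nM.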

Compound 4, concentration for 50% growth inhibition: 22000 nM
Estimate against measurement, compound 4: 1.1-fold (0.06 log units) above, within the range that was stated.
By their numbers in this assay, from the lowest: compound 2; then compound 3; then compounds 4 and 1 (each within the scatter of the next).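

In this assay, isopropyl in place of hydrogen on an amide-type nitrogen gives a 1.8-fold lower number from compound 1 to compound 4 (0.25 log units; within the scatter), the first step among the compounds shown that can be read at a single place. At this position, then, the amide hydrogen can give way to isopropyl without a difference that stands clear of the scatter, and compound 1 and compound 4 cannot be told apart on this read-out. No measurement at hand bears on the reason for this result.

This single step leaves open whether any other group on this nitrogen, such as a longer chain, a cyclopropyl ring or a chain ending in an amine or a carboxylic acid, would bring a step beyond the scatter. It also leaves open whether isopropyl would behave the same way with other groups elsewhere on the shared core.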